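The source may report more compounds than this note shows. Statements on the series, on what has been measured and on what is new or still open speak of the compounds shown alone.

Measured in a functional assay on MCF7 cells (Homo sapiens) for antiproliferative activity, read by MTT assay, with a stated time of 24 h; a lower number here means a stronger inhibitor, a higher number a weaker inhibitor:
- Compound 1 `CCCCNC(=O)COc1ccc(C(=O)c2c(CCCC)oc3ccccc23)cc1`: > 50000 nM, a limit of the assay and not a number
- Compound 2 `CCCCc1oc2ccccc2c1C(=O)c1ccc(OCC(=O)Nc2ccccc2)cc1`: 33600 nM
- Compound 3 `CCCCc1oc2ccccc2c1C(=O)c1ccc(OCC(=O)Nc2cccc(OC)c2)cc1`: 38500 nM

Compound 3 sits level with compound 2, a 1.1-fold higher number from compound 2 to compound 3 (0.06 log units; within the scatter). Both are weak inhibitors in this assay.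

Compound 4 `CCCCNC(=O)CCCOc1ccc(C(=O)c2c(CCCC)oc3ccccc23)cc1` carries 2-(butylcarbamoyl)ethyl in place of (3-methoxyphenyl)carbamoyl on a saturated chain carbon bound to an oxygen on an aromatic ring.

The closest evidence is the exchange of butyl for an aromatic ring on the amide-type nitrogen: an at least 1.4-fold lower number from compound 1 to compound 2 (0.17 log units; that floor lies within the scatter), and an at least 1.2-fold lower number from compound 1 to compound 3 (0.11 log units; that floor lies within the scatter). Both are only floors. For the measured compounds named here, no measured compound carries the longer chain, so its contribution is unknown. Returning to butyl suggests, at most, a slight rise, and a reading at the limit is quite possible.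

An estimated 1.2-fold higher number from compound 3 to compound 4 (0.07 log units; within the scatter) is expected, so no step beyond the scatter is foreseen. For compound 4 the expected value is 45000 nM, within an estimated range of 22000 nM to 90000 nM.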

Compound 4, half-maximal inhibitory concentration: > 50000 nM
Compound 4 was reported as a limit; the forecaster's own chance of this, stated with the estimate: 55%; middle value at least 1.1-fold (0.04 log units) from the limit.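

In this assay compound 4 gives > 50000 nM, a limit of the assay and not a number. At this position, 2-(butylcarbamoyl)ethyl therefore brings no activity that can be read, with an at least 1.2-fold higher number from compound 3 to compound 4 (0.11 log units; that floor lies within the scatter) and an at least 1.4-fold higher number from compound 2 to compound 4 (0.17 log units; that floor lies within the scatter), both only floors. The step between compound 1 and compound 4 cannot be read, so the effect of the longer chain stays hidden: the limit of > 50000 nM in this assay, at which 2 of the 4 values shown sit.

From the compounds shown here alone, how far compound 1 and compound 4 lie past that limit stays open. Also open, going by these compounds, is whether a carboxylic acid or an amine at the end of the longer chain would give a readable value.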